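The source may report more compounds than this note shows. Statements on the series, on what has been measured and on what is new or still open speak of the compounds shown alone.

Compound 1 `CC(C)(C)c1cc(C(C)(C)C)c2oc(C(c3ccccc3)c3c[nH]c4ccccc34)cc2c1` and compound 2 `Cc1[nH]c2ccccc2c1C(c1ccccc1)c1cc2cc(C(C)(C)C)cc(C(C)(C)C)c2o1` share one core. In a functional assay on SiHa cells (Homo sapiens) for cytotoxicity (a higher number here means a weaker inhibitor, a lower number a stronger inhibitor), compound 1 gives 61600 nM, and compound 2 gives 72000 nM. The change between them is methyl in place of hydrogen on an aromatic carbon, and it makes a step of a 1.2-fold higher number from compound 1 to compound 2 (0.07 log units; within the scatter). Compound 3 `COc1ccc(C(c2cc3ccccc3o2)c2c[nH]c3ccccc23)cc1` is built on another core; the difference between the two cores is not broken down here. In this assay compound 3 reaches only a limit of the assay, > 100000 nM, which is the limit of > 100000 nM in this assay, at which 1 of the 3 values shown sits. Compound 4 `COc1ccc(C(c2cc3ccccc3o2)c2c(C)[nH]c3ccccc23)cc1` carries the same change on the core of compound 3, namely (methyl in place of hydrogen on an aromatic carbon). Compound 4 is expected to remain at the limit or near it, estimated at 150000 nM, between 60000 nM and 400000 nM, because the earlier step was a 1.2-fold higher number from compound 1 to compound 2 (0.07 log units; within the scatter). For compound 4 the expected step is a step that the limit leaves unreadable from compound 3 to compound 4.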

Compound 4, half-maximal inhibitory concentration: > 100000 nM
Compound 4: a limit, no number; the forecaster's own chance of this, stated with the estimate: 75%; the middle value does not contradict the limit.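

Among the compounds shown here, compound 3 and compound 4 both stand at a limit of the assay, not at a number, so no step between them can be read in this assay. The compounds shown leave open whether methyl in place of hydrogen on an aromatic carbon changes anything on the core of compound 3.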